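The source may hold more compounds than are shown below. What is called first, only, known or untested is meant among the compounds shown, and "the series" means these compounds.

Measured compounds in a functional assay for antagonist activity at Adrenergic receptor alpha-1 (Rattus norvegicus); on this read-out higher numbers stand for weaker binding and lower numbers for tighter binding:
compound 1 `COc1cccc(OC)c1OCCNC[C@H]1Oc2ccccc2O[C@@H]1C(C)C`: 269 nM
compound 2 `COc1cccc(OC)c1OCCNC[C@H]1Oc2ccccc2O[C@H]1c1ccc(Cl)cc1`: 81.3 nM
compound 3 `COc1cccc(OC)c1OCCNC[C@H]1Oc2ccccc2O[C@@H]1c1ccc(Cl)cc1`: 7.08 nM

Compound 3 gives the lowest number of the three; compound 2 is nearest and compound 1 furthest, both beyond the scatter. The steps into compound 3 were a 38-fold lower number from compound 1 to compound 3 (1.58 log units; beyond the scatter) and an 11-fold lower number from compound 2 to compound 3 (1.06 log units; beyond the scatter), the latter read against (the fact that compounds 2 and 3 differ only in the configuration as drawn). Compound 4 `COc1ccc([C@H]2Oc3ccccc3O[C@@H]2CNCCOc2c(OC)cccc2OC)cc1` differs from compound 3 by methoxy in place of chloro on an aromatic carbon. Among the measured compounds shown here, neither measured step changes a substituent on the aryl ring, so neither bears directly on this change; the large aryl step shows only that this ring matters. A change within the scatter, or a small upward step, is expected in this assay. For compound 4 the estimate is 12 nM, range 4 nM to 40 nM, an expected step of a 1.7-fold higher number from compound 3 to compound 4 (0.23 log units; within the scatter).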

Compound 4, dissociation constant: 2.14 nM
The estimate for compound 4 lay 5.6-fold (0.75 log units) above the measured number; the measured number lies below the stated range.
By their numbers in this assay, from the lowest: compound 4; then compound 3; then compound 2; then compound 1.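

In this assay, the substituent on the aryl ring proves able to move the number on its own: methoxy in place of chloro gives a 3.3-fold lower number from compound 3 to compound 4 (0.52 log units; beyond the scatter) and so tightens binding further. The 4-methoxyphenyl group also widens the lead over isopropyl, with a 130-fold lower number from compound 1 to compound 4 (2.10 log units; beyond the scatter) as the result. Nothing given here accounts for the difference between methoxy and chloro at this position.

Going by these compounds, whether the trend extends to hydroxy, ethoxy or an amine at this position remains open. Also open, on these data alone, is whether methoxy would bring a similar step in the opposite configuration, that of compound 2.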